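Ring-nitrogen substituent in a thiazolidinone amide series

The source may report more compounds than this note shows. Statements on the series, on what has been measured and on what is new or still open speak of the compounds shown alone.

Measured so far:
Compound 1 `COc1ccccc1N1C(=O)CSC1C(=O)NCCCCc1ccccc1` gives 6% in a functional assay on U2OS cells (Homo sapiens) for inhibition, read by CCK-8 assay, with a stated time of 72 h, tested at 1 uM; on this read-out higher numbers stand for more inhibition at the one concentration tested (going by the name of the read-out) and lower numbers for less inhibition.
Compound 2 `CCN1C(=O)CSC1c1cccc(C(=O)NCCCCc2ccccc2)c1` gives 13% in this assay.
Compound 3 `O=C(NCCCCc1ccccc1)c1cccc(C2SCC(=O)N2c2cccc(F)c2)c1` gives 39% in this assay.

Compound 2 stands second highest of the three numbers. Its nearest neighbour is compound 1, whose value lies within the scatter of that of compound 2, so the two cannot be told apart. The furthest is compound 3, separated by a step beyond the scatter: a number 26 percentage points higher from compound 2 to compound 3 (beyond the scatter), brought about by 3-fluorophenyl in place of ethyl on an amide-type nitrogen in a ring.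

The step to compound 4 `CC(F)(F)c1cccc(N2C(=O)CSC2c2cccc(C(=O)NCCCCc3ccccc3)c2)c1` touches the same position: a group of 10 heavy atoms (8 carbon, 2 fluorine; one six-membered aromatic ring of carbon only) in place of a group of 2 heavy atoms (2 carbon; no ring), on an amide-type nitrogen in a ring. The entering group again brings a six-membered aromatic ring of carbon only, now carrying fluorine on a side group rather than on the ring itself. Among the measured compounds shown here, the one measured step that bears on this, from compound 2 to compound 3, was modest and upward, so a rise of similar order is expected. For the measured compounds named here, only a single step supports this, and the entering group is not identical, so the expectation is held loosely. Compound 4 is expected to give 35%, with a range from 15% to 55%. The expected step is a number 22 percentage points higher from compound 2 to compound 4 (beyond the scatter).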

Compound 4, a percentage reported as inhibition, at one concentration (the size of the read-out at that concentration, not a potency): 24%
Beside the measured number, compound 4's estimate is 11 percentage points above it; low and high end bracket the measured number.
By their numbers in this assay, from the lowest: compounds 1 and 2 (each within the scatter of the next); then compound 4; then compound 3.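

Notes on the ring nitrogen: in this assay, the gain over ethyl is not confined to 3-fluorophenyl, since the group of 10 heavy atoms with its six-membered aromatic ring of carbon only also gives a number 11 percentage points higher from compound 2 to compound 4 (beyond the scatter). The side group on that aromatic ring carries weight of its own, as 1,1-difluoroethyl in place of fluoro on an aromatic carbon gives a number 15 percentage points lower from compound 3 to compound 4 (beyond the scatter), so the two compounds with an aromatic ring at this nitrogen stand apart from each other as well as from the ethyl compound. No measurement on hand accounts for either step.

On these data alone, how plain phenyl on this nitrogen would compare with ethyl and with 3-fluorophenyl remains open, and with it the question of whether the aromatic ring alone is enough for the rise or whether a side group on it is also needed. Also open, as far as these compounds go, is whether a polar side group on that ring, such as an amine or a carboxylic acid, would keep the number above that of compound 2 at 13%.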